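Ester to acid on a fused bicyclic anilino core

The source may hold more compounds than are shown below. What is called first, only, known or untested is meant among the compounds shown, and "the series" means these compounds.

Measured compounds:
- compound 1 `Cc1oc2ncnc(Nc3cccc(Br)c3)c2c1C(=O)O`: 68000 nM
- compound 2 `CCOC(=O)c1c(C)oc2ncnc(Nc3ccc(OCc4cccc(F)c4)c(Cl)c3)c12`: 257000 nM
- compound 3 `CCOC(=O)c1c(C)oc2ncnc(Nc3cccc(Br)c3)c12`: the value is a limit of the assay, > 1000000 nM

In a functional assay on MCF7 cells (Homo sapiens) for cytotoxicity, read by MTT assay, with a stated time of 72 h (a higher number here means a weaker inhibitor, a lower number a stronger inhibitor), compound 1 gives 68000 nM. Compound 2 gives 257000 nM in this assay. For compound 3 this assay reports only a limit, > 1000000 nM; this is the limit of > 1000000 nM in this assay, at which 1 of the 3 values shown sits.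

Compound 3 and compound 1 differ in one place, (hydrogen in place of ethyl on an oxygen next to a carbonyl group). This change gives an at least 14-fold lower number from compound 3 to compound 1 (1.16 log units; beyond the scatter); as compound 3 sits at the limit, the true size of that step may be larger than stated.

Compound 2 and compound 4 `Cc1oc2ncnc(Nc3ccc(OCc4cccc(F)c4)c(Cl)c3)c2c1C(=O)O` differ in the same place, (hydrogen in place of ethyl on an oxygen next to a carbonyl group); the place is the same word for word, so this is the same change. The difference between the cores of compound 2 and compound 3 is not broken down here, so the two pairs differ in the rest of the molecule, and the second step need not match the first.

The expectation for compound 4 rests on compound 2 at 257000 nM and on the step of an at least 14-fold lower number from compound 3 to compound 1 (1.16 log units; beyond the scatter). The step from compound 2 to compound 4 in this assay is estimated as a 13-fold lower number from compound 2 to compound 4 (1.11 log units; beyond the scatter). For compound 4 the expected value in this assay is 20000 nM, with a range from 5000 nM to 120000 nM.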

Compound 4, half-maximal inhibitory concentration: 46000 nM
Estimate against measurement, compound 4: 2.3-fold (0.36 log units) below; measured number inside the range.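

In this assay, going from ethoxycarbonyl to carboxy gives a 5.6-fold lower number from compound 2 to compound 4 (0.75 log units; beyond the scatter), so the lower number seen when the same change was made on the core of compound 3 recurs on the core of compound 2. The direction therefore carries over between the two cores, but the size of the change cannot be carried over with any confidence: the same change on two cores in this assay, an at least 14-fold lower number (1.16 log units; beyond the scatter) from compound 3 to compound 1 and a 5.6-fold lower number (0.75 log units; beyond the scatter) from compound 2 to compound 4; the limit leaves it open whether they differ
Compound 3 is reported only as a limit, > 1000000 nM, and the two pairs together give a shared direction on these two cores, not a rule for the rest of the series.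

The compounds shown leave open whether the lower number is specific to the carboxylic acid or would also appear with another group in the same place, such as a primary amide, a methyl ester or a longer alkyl ester. They also leave open how the change behaves on further cores, for instance one with a chlorine or a methoxy group as the only substituent on the aniline ring, which would show whether the direction holds beyond these two pairs.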